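A few compounds are considered here, and "the series" means these few. Any claim that something is new, unique, unknown or untested is made for them only; others in the source may bear on it.

The measured compounds:

Compound 1 `COc1ccc(-c2ccnc(C(=O)Nc3ccc(Oc4ccnc5[nH]ccc45)cc3)n2)cc1` gives 12400 nM in a functional assay on MCF7 cells (Homo sapiens) for cytotoxicity, read by MTT assay, with a stated time of 72 h; a lower number here means a stronger inhibitor, a higher number a weaker inhibitor.
Compound 2 `O=C(Nc1ccc(Oc2ccnc3[nH]ccc23)cc1)c1cc(-c2ccccc2)ncn1` gives 20 nM in this assay.
Compound 3 `COc1ccc(-c2ccnc(C(=O)Nc3ccc(Oc4ccnc5[nH]ccc45)c(F)c3)n2)cc1` gives 8960 nM in this assay.

Compound 2 stands far below compound 1 and compound 3, both gaps beyond the scatter. How the core of compound 1 and the core of compound 2 differ is not broken down here. From compound 1 to compound 3 the change is fluoro in place of hydrogen on an aromatic carbon, and it gave a 1.4-fold lower number from compound 1 to compound 3 (0.14 log units; within the scatter).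

Compound 4 `O=C(Nc1ccc(Oc2ccnc3[nH]ccc23)c(F)c1)c1cc(-c2ccccc2)ncn1` has not yet been measured. It carries the same change relative to compound 2: fluoro in place of hydrogen on an aromatic carbon. For compound 4 the step is expected to be a 1.3-fold lower number from compound 2 to compound 4 (0.12 log units; within the scatter), much like the earlier one, because that earlier step was a 1.4-fold lower number from compound 1 to compound 3 (0.14 log units; within the scatter). Compound 4 is thus expected near 15 nM, with an estimated range from 6 nM to 40 nM.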

Compound 4, half-maximal inhibitory concentration: 4640 nM
The estimate for compound 4 lay 310-fold (2.49 log units) below the measured number; measured number above the stated range.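

In this assay, fluoro in place of hydrogen on an aromatic carbon gave a 230-fold higher number from compound 2 to compound 4 (2.37 log units; beyond the scatter). Among the compounds shown here, the same change did not carry over from one core to the other, and the two steps differ: the same change on two cores in this assay, a 1.4-fold lower number (0.14 log units; within the scatter) from compound 1 to compound 3 and a 230-fold higher number (2.37 log units; beyond the scatter) from compound 2 to compound 4, 320-fold (2.51 log units) apart, beyond the scatter of two such steps This shows that the step on the core of compound 1 was no guide to the step on the core of compound 2, but it does not show which feature of the two cores sets the steps apart, and one pair on each core gives no rule for the series.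

The compounds shown leave open whether chloro or methyl at the same place would follow fluoro on the core of compound 2. They also leave open how an amine there would behave.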